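The source may hold more compounds than are shown below. What is called first, only, known or untested is meant among the compounds shown, and "the series" means these compounds.

Compound 1 `COc1ccc(/C=C\c2cc(OC)c(OC)c(OC)c2)cc1OCc1ccc(CNC(C)(C)C(=O)O)cc1` carries a (1-carboxy-1-methylethyl)amino group on a saturated chain carbon bound to an aromatic carbon. In a functional assay on HeLa cells (Homo sapiens) for antiproliferative activity, read by CCK-8 assay, with a stated time of 48 h (on this read-out lower numbers stand for stronger inhibition and higher numbers for weaker inhibition), compound 1 reaches only the limit > 10000 nM, a limit of the assay rather than a number. Compound 2 `COc1ccc(/C=C\c2cc(OC)c(OC)c(OC)c2)cc1OCc1ccc(CN2C[C@H](O)C[C@@H]2C(=O)O)cc1` likewise stops at the limit > 10000 nM in this assay. Compound 3 `COc1ccc(/C=C\c2cc(OC)c(OC)c(OC)c2)cc1OCc1ccc(CN2CC(C(=O)O)C2)cc1` gives 6500 nM in this assay. The readable steps are an at least 1.5-fold lower number from compound 1 to compound 3 (0.18 log units; that floor lies within the scatter) and an at least 1.5-fold lower number from compound 2 to compound 3 (0.18 log units; that floor lies within the scatter), while the step that the two limits leave unreadable from compound 1 to compound 2 cannot be sized, since both of its values sit at the limit (the limit of > 10000 nM in this assay, at which 2 of the 3 values shown sit). Compound 4 `COc1ccc(/C=C\c2cc(OC)c(OC)c(OC)c2)cc1OCc1ccc(CN[C@H](C(=O)O)[C@@H](C)O)cc1` differs from compound 1 by 1-carboxy-2-hydroxypropyl in place of 1-carboxy-1-methylethyl on an amine nitrogen. As in compound 2, the entering group combines a carboxylic acid with a hydroxyl, and no readable step points to a lower number for compound 4. In this assay compound 4 is therefore expected to show a step that the limit leaves unreadable from compound 1 to compound 4. The estimate for compound 4 is 15000 nM, with a range from 6000 nM to 40000 nM.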

Compound 4, half-maximal inhibitory concentration: > 10000 nM
Compound 4: no number, only a limit; the forecaster's own chance of this, stated with the estimate: 70%; the middle value does not contradict the limit.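

In this assay compound 4 gives > 10000 nM, which is a limit of the assay and not a number. Among the compounds shown here, with (1-carboxy-2-hydroxypropyl)amino on the saturated chain carbon, the comparison with the only numbered compound shows an at least 1.5-fold higher number from compound 3 to compound 4 (0.18 log units; that floor lies within the scatter), while the steps from compound 1 and from compound 2 to compound 4 cannot be read. A second open-chain amino acid group thus ends at the same limit: the limit of > 10000 nM in this assay, at which 3 of the 4 values shown sit.

On these data alone, what compound 1, compound 2 and compound 4 would give as numbers stays open. Also open, as far as these compounds go, is whether a simple amine without a carboxylic acid, or a methyl ester of that acid, on this carbon would give a number in this assay.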